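The compounds below may be only part of what the source reports. "The series", "measured", "known", "first", "only" and "open" are said of these compounds alone.

Series notes. Going by the values given here, the two measured members share a core but differ in more than one place, so no single step links them. Compound 1 `Fc1cc(Cl)ccc1-c1ccc(Cn2nnc3ccccc32)cn1` is the more cleared of the pair: in an ADME assay on microsomes from liver (Mus musculus, strain NMRI) for metabolic stability, tested at 2.5 uM (on this read-out lower numbers stand for slow clearance and higher numbers for fast clearance), compound 1 gives 3.4 mL/min/g. Among the compounds with values here, compound 2 `Fc1ccc(Cn2nnc3c(Br)cccc32)cc1` carries a fluoro group and a bromo group on its two aromatic rings; in this assay compound 2 gives 1 mL/min/g, the lowest of the two numbers recorded, with compound 1 as its only neighbour at a number higher by a margin beyond the usual scatter.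

Compound 3 `Brc1ccc(Cn2nnc3c(Br)cccc32)cc1` has not yet been run. The change from compound 2 to compound 3 is bromo in place of fluoro on an aromatic carbon. Within the data shown here, no measured pair in this set carries this same exchange, so the recorded values give no direct guide to its size. The step of a 1.6-fold higher number from compound 2 to compound 3 (0.20 log units; within the scatter) is expected to be modest and, if anything, upward, not clearly outside the scatter. The estimate for compound 3 in this assay is 1.6 mL/min/g, with a range from 0.6 mL/min/g to 4.5 mL/min/g.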

Compound 3, intrinsic clearance in a liver preparation (reported as CLH), per the amount of preparation that the assay uses: 2.6 mL/min/g
Beside the measured number, compound 3's estimate is 1.6-fold (0.21 log units) below it, within the range that was stated.
By their numbers in this assay, from the lowest: compound 2; then compounds 3 and 1 (each within the scatter of the next).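

Bromo in place of fluoro, on an aromatic carbon para to a large group, gives the series its first change that can be read in one place: in this assay, the step is a 2.6-fold higher number from compound 2 to compound 3 (0.41 log units; beyond the scatter). This shows that the position is not silent on this read-out: exchanging one halogen for another is enough to carry the number beyond the usual scatter, even though the change adds or removes no ring, hydrogen-bond donor or acceptor, or net charge. No available data bear on what lies behind this step.

As far as these compounds go, with only fluoro and bromo to compare at this position, two points cannot establish a trend, and it remains open whether a chloro group, a methoxy group, a nitrile or an amine there would fall near these numbers or well away from them. Also open, from the compounds shown here alone, is whether bromo in place of fluoro would give a step of similar size and direction elsewhere, including on the core of compound 1.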